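The compounds below may be only part of what the source reports. "The series", "measured", "known", "first", "only" and "open" are said of these compounds alone.

Measured so far:
Compound 1 `COc1cc2c(Nc3nc4ccc(C(=O)Nc5c(C)cccc5C)cc4s3)ncnc2cc1OCCCN1CCCCC1`: in a functional assay on A549 cells (Homo sapiens) for cytotoxicity, read by WST assay, with a stated time of 72 h (a higher number here means a weaker inhibitor, a lower number a stronger inhibitor), compound 1 gives > 100000 nM, which is a limit of the assay and not a number.
Compound 2 `COc1cc2c(Nc3nc4ccc(C(=O)Nc5c(C)cc(C)cc5C)cc4s3)ncnc2cc1OCCCN1CCCCC1C`: in this assay compound 2 gives 5800 nM.
Compound 3 `CCN(CC)CCCOc1cc2ncnc(Nc3nc4ccc(C(=O)Nc5c(C)cc(C)cc5C)cc4s3)c2cc1OC`: in this assay compound 3 gives 5700 nM.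

Compound 3 carries the lowest of the two numbers available, but compound 2 sits nearest and the gap a 1.0-fold lower number from compound 2 to compound 3 (0.01 log units; within the scatter) lies within the scatter, so neither can be called stronger than the other. For compound 1 only the limit of > 100000 nM in this assay, at which 1 of the 3 values shown sits, is known.

Compound 4 `COc1cc2c(Nc3nc4ccc(C(=O)Nc5c(C)cc(C)cc5C)cc4s3)ncnc2cc1OCCCN1CCCCC1` differs from compound 3 by piperidin-1-yl in place of diethylamino on a saturated chain carbon, three bonds along the chain from an oxygen on an aromatic ring. Among the measured compounds shown here, one measured step bears on this: a 1.0-fold lower number from compound 2 to compound 3 (0.01 log units; within the scatter), which exchanged a cyclic amine at the same place for the open diethylamino without moving the number beyond the scatter. The step to compound 4 reverses that exchange, now with the unmethylated ring. For the measured compounds named here, compound 1 also carries piperidin-1-yl at this place, but it differs from compound 4 elsewhere and only a limit is known for it, so it gives no usable step. No movement beyond the scatter is therefore expected in this assay; the expected step is a 1.0-fold lower number from compound 3 to compound 4 (0.02 log units; within the scatter). Compound 4 is estimated at 5500 nM, within 2500 nM to 13000 nM.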

Compound 4, half-maximal inhibitory concentration: 10300 nM
Estimate against measurement, compound 4: 1.9-fold (0.27 log units) below, and the stated range covers the measured number.
By their numbers in this assay, from the lowest: compounds 3, 2 and 4 (each within the scatter of the next). At a limit, above all of these: compound 1.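

In this assay, piperidin-1-yl in place of diethylamino on the saturated chain carbon gives a 1.8-fold higher number from compound 3 to compound 4 (0.26 log units; within the scatter), and hydrogen in place of methyl on a saturated ring carbon gives a 1.8-fold higher number from compound 2 to compound 4 (0.25 log units; within the scatter). Neither the open amine against the ring nor the ring methyl therefore moves the number beyond the scatter, so this end of the chain has so far tolerated all three amines shown. Among the compounds shown here, the one change beyond the scatter lies elsewhere, with methyl in place of hydrogen on an aromatic carbon: an at least 9.7-fold lower number from compound 1 to compound 4 (0.98 log units; beyond the scatter). The value of compound 1 is a limit of the assay and not a number: the limit of > 100000 nM in this assay, at which 1 of the 4 values shown sits.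

Going by these compounds, whether a ring amine carrying a further hetero atom, such as morpholine or piperazine, or a shorter or longer chain in place of the 3-(piperidin-1-yl)propyl group stays in the same range remains open. Also open, on these data alone, is whether ethyl or chlorine on that aromatic carbon would give a step like that of methyl.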